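Sulfonamide nitrogen substitution on the thiazolidinone core

The source may report more compounds than this note shows. Statements on the series, on what has been measured and on what is new or still open speak of the compounds shown alone.

Compound 2 `NS(=O)(=O)c1ccc(NC2=NC(=O)/C(=C\c3coc4ccccc4c3=O)S2)cc1` gives 2230 nM in a functional assay on A549 cells (Homo sapiens) for cytotoxicity, read by sulforhodamine B assay, with a stated time of 72 h (a lower number here means a stronger inhibitor, a higher number a weaker inhibitor), the lowest of the two numbers in hand. Compound 1 `O=C1/C(=C/c2coc3ccccc3c2=O)N=C(c2ccc(Cl)cc2)N1c1ccc(S(=O)(=O)Nc2ncccn2)cc1` gives 59000 nM in this assay. For compound 3 `O=C1/C(=C/c2coc3ccccc3c2=O)N=C(c2ccc(Cl)cc2)N1c1ccc(S(=O)(=O)Nc2nccs2)cc1` the result in this assay is a limit of the assay, > 100000 nM, so that compound 3 sits at the limit of > 100000 nM in this assay, at which 1 of the 3 values shown sits. Within the data shown here, the single measured step on a sulfonamide nitrogen, an at least 1.6-fold higher number from compound 1 to compound 3 (0.22 log units; that floor lies within the scatter), rests on that limit, stays within the scatter, and exchanges one heteroaryl for another on a different core. Among the measured compounds shown here, compound 4 `O=C1N=C(Nc2ccc(S(=O)(=O)Nc3nccs3)cc2)S/C1=C/c1coc2ccccc2c1=O` differs from compound 2 by 1,3-thiazol-2-yl in place of hydrogen on a sulfonamide nitrogen; no measured pair sets hydrogen against a heteroaryl at that nitrogen, so the step from compound 1 to compound 3 offers only faint guidance toward a weaker inhibitor. For compound 4 a step of a 2.2-fold higher number from compound 2 to compound 4 (0.35 log units; beyond the scatter) is expected in this assay, toward a higher number, with wide uncertainty. Compound 4 is estimated at 5000 nM, within 1200 nM to 30000 nM.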

Compound 4, half-maximal inhibitory concentration: > 100000 nM
Compound 4 ended at the assay's limit (the forecaster's own chance of this, stated with the estimate: 5%); middle value at least 20-fold (1.30 log units) from the limit.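

Working notes on the sulfonamide nitrogen: in this assay, 1,3-thiazol-2-yl in place of hydrogen gives an at least 44-fold higher number from compound 2 to compound 4 (1.65 log units; beyond the scatter), the first measured comparison of hydrogen with a heteroaryl at this position. The earlier step on that nitrogen, an at least 1.6-fold higher number from compound 1 to compound 3 (0.22 log units; that floor lies within the scatter), exchanged one heteroaryl for another on a different core and showed no change beyond the scatter, whereas this pair shows that the position can matter on the core of compound 2. The step rests on a limit of the assay for compound 4, so it gives a floor and not a size: the limit of > 100000 nM in this assay, at which 2 of the 4 values shown sit.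

As far as these compounds go, whether a methyl or acetyl group on this nitrogen would have the same effect as 1,3-thiazol-2-yl remains open. The pair also leaves open how large the step truly is.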